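The source may report more compounds than this note shows. Statements on the series, on what has been measured and on what is new or still open speak of the compounds shown alone.

Series notes, step from compound 1 to compound 3. In a functional assay on HepG2 cells (Homo sapiens) for cytotoxicity, read by MTT assay, with a stated time of 72 h (on this read-out higher numbers stand for weaker inhibition and lower numbers for stronger inhibition), compound 1 `Cc1cc(=O)n(-c2ccc(Br)cc2F)nc1C(=O)Nc1ccc(Oc2ncnc3ccsc23)cc1` gives 10600 nM, the highest of the two numbers in hand. Compound 2 `Cc1cc(=O)n(-c2cccc(F)c2)nc1C(=O)Nc1ccc(Oc2ncnc3ccsc23)cc1` gives 10200 nM in this assay; the step of a 1.0-fold lower number from compound 1 to compound 2 (0.02 log units; within the scatter) lies within the scatter, so these two values show no order. Compound 3 `Cc1cc(=O)n(-c2ccc(Br)cc2F)nc1C(=O)Nc1ccc(Oc2ncnc3ccsc23)c(F)c1` has not been measured in this assay. It differs from compound 1 by fluoro in place of hydrogen on an aromatic carbon. For the measured compounds named here, no measured step bears on that position: the only step in hand, a 1.0-fold lower number from compound 1 to compound 2 (0.02 log units; within the scatter), concerns the group on the aromatic nitrogen and was itself within the scatter. Nothing in the series therefore points to a step beyond the scatter in this assay for this change, and the expected step is a 1.1-fold lower number from compound 1 to compound 3 (0.03 log units; within the scatter). For compound 3 the estimate in this assay is 10000 nM, with a range from 4000 nM to 25000 nM.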

Compound 3, half-maximal inhibitory concentration: 3350 nM
For compound 3 the middle estimate is 3.0-fold (0.47 log units) above the measured one; the whole stated range lies above it.
By their numbers in this assay, from the lowest: compound 3; then compounds 2 and 1 (each within the scatter of the next).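

In this assay, for the compounds shown here, fluoro in place of hydrogen on the aromatic carbon gives a 3.2-fold lower number from compound 1 to compound 3 (0.50 log units; beyond the scatter), the first step that lies beyond the scatter; the earlier step, a 1.0-fold lower number from compound 1 to compound 2 (0.02 log units; within the scatter), concerned the group on the aromatic nitrogen and showed no order. This carbon, on a six-membered aromatic ring of carbon only, ortho to a large group and meta to a large group, is therefore a place where adding a single fluorine atom changes the number, though the step is modest and rests on one pair. Nothing measured here bears on the reason for this step.

The compounds shown leave open whether chloro, methoxy or an amine on the same carbon would move the number in the same direction and by a similar size. As far as these compounds go, it also remains open whether fluoro there gives a similar step when the aromatic nitrogen carries the 3-fluorophenyl group of compound 2.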